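Chloro for fluoro on the benzyl group of compound 1

The source may hold more compounds than are shown below. What is called first, only, known or untested is meant among the compounds shown, and "the series" means these compounds.

In a functional assay on 4T1 cells (Mus musculus) for cytotoxicity, read by MTT assay, with a stated time of 24 h (a higher number here means a weaker inhibitor, a lower number a stronger inhibitor), compound 1 (`COc1ccc(/C=C2\CN(C(=S)SCc3cn(Cc4ccccc4F)nn3)C/C(=C\c3ccc(OC)cc3)C2=O)cc1`) gives 49900 nM and stands level with the other two measured compounds. Compound 2 (`O=C1/C(=C/c2ccccc2F)CN(C(=S)SCc2cn(Cc3ccccc3Cl)nn2)C/C1=C\c1ccccc1F`) gives 43600 nM and compound 3 (`COc1ccc(/C=C2\CN(Cc3cn(Cc4ccccc4F)nn3)C/C(=C\c3ccc(OC)cc3)C2=O)cc1`) gives 39400 nM here, so all three lie within the scatter of one another.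

Compound 4 (`COc1ccc(/C=C2\CN(C(=S)SCc3cn(Cc4ccccc4Cl)nn3)C/C(=C\c3ccc(OC)cc3)C2=O)cc1`) has chloro in place of fluoro on an aromatic carbon, which turns 2-fluorobenzyl into 2-chlorobenzyl. Going by the values given here, no measured pair isolates this change, so its size cannot be read directly from the data. Among the compounds with values here, the one measured compound with 2-chlorobenzyl is compound 2, at 43600 nM and within the scatter of compound 1, so no step beyond the scatter is expected in either direction. The estimated step is a 1.1-fold lower number from compound 1 to compound 4 (0.04 log units; within the scatter) and is expected to stay inside the scatter. In this assay the estimate for compound 4 is 45000 nM (expected range 25000 nM to 80000 nM).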

Compound 4, half-maximal inhibitory concentration: > 100000 nM
Compound 4 gave a limit, no number; the forecaster's own chance of this, stated with the estimate: 5%; middle value at least 2.2-fold (0.34 log units) from the limit.
By their numbers in this assay, from the lowest: compounds 3, 2 and 1 (each within the scatter of the next). At a limit, above all of these: compound 4.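

In this assay, the swap of 2-fluorobenzyl for 2-chlorobenzyl now has its first reading from a pair that differs in one place only, and that reading runs an at least 2.0-fold higher number from compound 1 to compound 4 (0.30 log units; that floor lies within the scatter). This single halogen exchange, on an aromatic carbon ortho to a large group, therefore moves the result in the direction of a higher number, but the floor of the step does not by itself clear the scatter. Compound 4 is a limit of the assay and not a number: the limit of > 100000 nM in this assay, at which 1 of the 4 values shown sits.

On these data alone, how far compound 4 lies past that limit remains open, so the true size of the step cannot be stated. Also open, as far as these compounds go, is how a plain benzyl, a 2-bromobenzyl or a 2-methoxybenzyl would read at this position on the core of compound 1.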